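Swapping the acid-bearing group on the ring nitrogen's neighbour

A few compounds are considered here, and "the series" means these few. Any claim that something is new, unique, unknown or untested is made for them only; others in the source may bear on it.

Swapping the acid-bearing group on the saturated chain carbon bound to the amine nitrogen in the ring

Compounds measured so far:
Compound 1 `O=C(O)c1ccc2nc(CN3CCC[C@H](O[C@H](CO)c4cc(Cl)cc(Cl)c4)[C@@H]3c3ccccc3)[nH]c2c1`: 43000 nM
Compound 2 `Cc1cc(C(=O)O)ccc1CN1C(C)CC[C@H](O[C@H](CO)c2cc(Cl)cc(Cl)c2)[C@@H]1c1ccccc1`: 130000 nM
Compound 3 `Cc1cc(C(=O)O)ccc1CN1CCC[C@H](O[C@H](CO)c2cc(Cl)cc(Cl)c2)[C@@H]1c1ccccc1F`: "nd" (no result reported)

In an assay on isolated protein for activation of cGMP-dependent protein kinase 1 (Homo sapiens), read by ADP-Glo, with stated times of 30 min and 2 h (on this read-out lower numbers stand for an effect already at smaller amounts and higher numbers for an effect only at larger amounts of compound), compound 1 gives 43000 nM, the lowest of the two numbers available. Compound 2 gives 130000 nM, a higher number by a margin that lies beyond the usual scatter of this assay; compound 2 differs from compound 1 in more than one place, so no single-step comparison is drawn. Compound 3 carries no reported number in this assay.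

Compound 4 `Cc1nc(C(=O)O)ccc1CN1CCC[C@H](O[C@H](CO)c2cc(Cl)cc(Cl)c2)[C@@H]1c1ccccc1` differs from compound 1 at one site: a group of 10 heavy atoms (7 carbon, 1 nitrogen, 2 oxygen; one six-membered aromatic ring with 1 hetero atom) in place of a group of 12 heavy atoms (8 carbon, 2 nitrogen, 2 oxygen; one five-membered aromatic ring with 2 hetero atoms, one six-membered aromatic ring of carbon only), on a saturated chain carbon bound to an amine nitrogen in a ring. Nothing measured here isolates this change, so the expectation rests on the two numbers shown. Compound 2 also carries a six-membered acid-bearing ring on that saturated carbon rather than the group of compound 1. Because in this assay compound 2 gives 130000 nM, a step toward a higher number of a 1.9-fold higher number from compound 1 to compound 4 (0.27 log units; within the scatter) is expected. Compound 4 is thus estimated at 80000 nM, with a range of 30000 nM to 250000 nM.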

Compound 4, half-maximal effective concentration: 144000 nM
The estimate for compound 4 lay 1.8-fold (0.26 log units) below the measured number; measured number inside the range.
By their numbers in this assay, from the lowest: compound 1; then compounds 2 and 4 (each within the scatter of the next).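

Among the compounds shown here, this is the first step that changes only the group on the saturated chain carbon bound to an amine nitrogen in a ring, and it shows that the number responds to a change at this place. In this assay, a group of 10 heavy atoms with one six-membered aromatic ring with 1 hetero atom, in place of a group of 12 heavy atoms with one five-membered aromatic ring with 2 hetero atoms and one six-membered aromatic ring of carbon only, gives a 3.3-fold higher number from compound 1 to compound 4 (0.52 log units; beyond the scatter) and the larger group keeps the lower number of this pair. No further measurement bears on why the number moves. The compounds shown leave open which part of the exchanged group accounts for this step, and whether its carboxylic acid is needed at all. A tetrazole or a primary amide in place of that carboxylic acid, on the group of compound 1, would speak to the second question.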